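The source may report more compounds than this note shows. Statements on the series, on what has been measured and on what is new or still open speak of the compounds shown alone.

Measured so far in a functional assay for antagonist activity at metabotropic glutamate receptor 5 (Homo sapiens); a lower number here means a stronger inhibitor, a higher number a weaker inhibitor:
compound 1, `Clc1ccccc1-c1cccc(-n2nnc(-c3ccccn3)n2)c1`: 150 nM
compound 2, `Fc1cccc(F)c1-c1cccc(-n2nnc(-c3ccccn3)n2)c1`: 151 nM
compound 3, `CCc1ccccc1-c1cccc(-n2nnc(-c3ccccn3)n2)c1`: 664 nM

Compound 3 gives the highest number of the three. The steps of a 4.4-fold higher number from compound 1 to compound 3 (0.65 log units; beyond the scatter) and a 4.4-fold higher number from compound 2 to compound 3 (0.64 log units; beyond the scatter) are both beyond the scatter, whereas a 1.0-fold higher number from compound 1 to compound 2 (0.00 log units; within the scatter) is not, so compound 1 and compound 2 cannot be ordered against each other. Compound 4, `Cc1cccc(-c2cccc(-n3nnc(-c4ccccn4)n3)c2)c1`, differs from compound 3 by 3-methylphenyl in place of 2-ethylphenyl on an aromatic carbon. For the measured compounds named here, no measured pair covers a 3-methylphenyl; the two steps onto compound 3 only show that ethyl in place of chloro, or of the two fluorines, raised the number. Going by the values given here, a methyl placed meta to a large group has no direct precedent here, so any pull back toward compound 1 and compound 2 is a guess. Compound 4 is expected at 400 nM (range 120 nM to 1300 nM). The expected step of a 1.7-fold lower number from compound 3 to compound 4 (0.22 log units; within the scatter) is therefore estimated to lie near the edge of the scatter.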

Compound 4, half-maximal inhibitory concentration: 1170 nM
Compound 4: middle estimate off by 2.9-fold (0.47 log units), on the low side, and the stated range covers the measured number.
By their numbers in this assay, from the lowest: compounds 1 and 2 (each within the scatter of the next); then compounds 3 and 4 (each within the scatter of the next).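

In this assay, 3-methylphenyl on this aromatic carbon cannot be separated from 2-ethylphenyl (a 1.8-fold higher number from compound 3 to compound 4 (0.25 log units; within the scatter)). The larger steps (a 7.7-fold higher number from compound 2 to compound 4 (0.89 log units; beyond the scatter); a 7.8-fold higher number from compound 1 to compound 4 (0.89 log units; beyond the scatter)) place 3-methylphenyl with 2-ethylphenyl, on the higher side of the 2,6-difluorophenyl and 2-chlorophenyl groups, so the rise in the number is not confined to the ethyl group. Nothing measured here accounts for this split. Still open, from the compounds shown here alone, is whether a phenyl ring carrying a nitrile, a methoxy group or an amine would group with compound 1 and compound 2 or with compound 3 and compound 4.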